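Dihydropyridine esters: trifluoroethyl to phenoxypropyl at the ester oxygen

The source may hold more compounds than are shown below. What is called first, only, known or untested is meant among the compounds shown, and "the series" means these compounds.

Measured so far in a functional assay on HEK293 cells for antagonist activity at Voltage-dependent L-type calcium channel subunit alpha-1C (Oryctolagus cuniculus), read by FLIPR; a lower number here means a stronger inhibitor, a higher number a weaker inhibitor:
compound 1 `COC(=O)C1=C(C)NC(C)=C(C(=O)OCC(F)(F)F)C1c1cccc([N+](=O)[O-])c1` gives 16 nM
compound 2 `CCOC(=O)C1=C(C)NC(C)=C(C(=O)OC=O)C1c1cccc([N+](=O)[O-])c1` gives 33300 nM

For the measured compounds named here, compound 1 holds the lower of the two numbers in this assay; the value of compound 2 lies far above it, beyond the usual scatter, though the two structures differ in more than one place, so the pair yields no single step.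

The next compound, compound 3 `COC(=O)C1=C(C)NC(C)=C(C(=O)OCCCOc2ccccc2)C1c1cccc([N+](=O)[O-])c1`, is built from compound 1 by one change: 2-phenoxyethyl in place of trifluoromethyl on a saturated chain carbon bound to an oxygen next to a carbonyl group. The 2,2,2-trifluoroethoxy ester of compound 1 thus becomes a 3-phenoxypropoxy ester; the rest of the shared core is untouched.

Going by the values given here, no measured pair isolates this change, so the expectation rests on compound 1 alone. A step of a 1.3-fold higher number from compound 1 to compound 3 (0.10 log units; within the scatter) is expected, that is no change beyond the scatter, with a wide margin. Compound 3 is therefore estimated at 20 nM, in the range 4 nM to 120 nM.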

Compound 3, half-maximal inhibitory concentration: 9 nM
For compound 3 the middle estimate is 2.2-fold (0.35 log units) above the measured one, and the stated range covers the measured number.
By their numbers in this assay, from the lowest: compounds 3 and 1 (each within the scatter of the next); then compound 2.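

On a saturated chain carbon bound to an oxygen next to a carbonyl group, 2-phenoxyethyl in place of trifluoromethyl gives a 1.8-fold lower number from compound 1 to compound 3 (0.25 log units; within the scatter) in this assay, so the two esters cannot be told apart in this read-out. This first single-place step in the series shows that this place accepts a six-membered aromatic ring and an ether oxygen with no change beyond the scatter, and that the fluorines of compound 1 are not required to stay in this range. No measurement at hand bears on why the two groups read alike.

As far as these compounds go, whether a tertiary amine, a carboxylic acid or a longer chain at this place would also hold the number remains open. Also open is which of its two differences from compound 1 accounts for the much higher number of compound 2.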